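Moving the Chlorine Around the Aromatic Ring

This account rests on a few compounds, and the source may have more. Where it says the series, first, only, none or still open, it means among the compounds named here.

Of the compounds shown here, three sharing one core have been tested in a functional assay on the whole organism (strain Swiss) with Mus musculus as the target, in the maximal electroshock model, with a stated time of 0.5 h, at a dose of 300 mg/kg by the intraperitoneal route; on this read-out lower numbers stand for a weaker effect and higher numbers for a stronger effect at the one dose given. Compound 1 `CCC(C(=O)N1CCOCC1)N1C(=O)CCC1=O` gives 0%. Compound 2 `CCC(C(=O)N1CCN(c2ccc(Cl)cc2)CC1)N1C(=O)CCC1=O` gives 0%, level with compound 1 at the digits shown and together the lowest of the three numbers. Within the data shown here, compound 3 `CC(C(=O)N1CCN(c2ccc(Cl)cc2)CC1)N1C(=O)CCC1=O` gives 100%; the single measured step, a number 100 percentage points higher from compound 2 to compound 3 (beyond the scatter), is a large rise that comes with hydrogen in place of methyl on a saturated chain carbon, two bonds along the chain from an amide-type nitrogen in a ring and a carbonyl carbon.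

Compound 4 `CCC(C(=O)N1CCN(c2ccccc2Cl)CC1)N1C(=O)CCC1=O` is not yet measured. It differs from compound 2 in one place: 2-chlorophenyl in place of 4-chlorophenyl on an amine nitrogen in a ring. Among the measured compounds shown here, no measured step touches this place; the only step measured concerns the chain carbon, not the aromatic ring, so it offers no direct guide. Compound 2 sits at 0%, and nothing measured shows that shifting the chlorine alone moves this read-out. Compound 4 is therefore expected to stay near the floor, with a rise of a number 20 percentage points higher from compound 2 to compound 4 (beyond the scatter) allowed for but not required. The estimate for compound 4 is 20%, within 0% to 80%.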

Compound 4, a percentage reported as activity, at one dose (the size of the read-out at that dose, not a potency): 25%
Compound 4: middle estimate off by 5 percentage points, on the low side; low and high end bracket the measured number.
By their numbers in this assay, from the lowest: compounds 1 and 2 (each within the scatter of the next); then compound 4; then compound 3.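

In this assay the place of the chlorine on the aromatic ring matters by itself: 2-chlorophenyl in place of 4-chlorophenyl, with the same atoms joined differently, gives a number 25 percentage points higher from compound 2 to compound 4 (beyond the scatter) and so lifts the read-out off the floor only modestly. Among these compounds, this is the first sign that the group on the amine nitrogen in a ring can move this number, as the earlier step touched only the chain carbon. No measurement here bears on why the shift raises the read-out.

On these data alone, whether an unsubstituted phenyl, or a fluorine or a methoxy group on the ring, would do the same remains open. Also open, as far as these compounds go, is what 2-chlorophenyl would do on the core of compound 3, which carries hydrogen in place of methyl on the chain carbon.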